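The source may report more compounds than this note shows. Statements on the series, on what has been measured and on what is new or still open speak of the compounds shown alone.

Series notes, step from compound 2 to compound 3.

Of the compounds shown here, two of the shared core have been measured in a functional assay on PCO3 cells (Homo sapiens) for cytotoxicity, read by sulforhodamine B assay; on this read-out lower numbers stand for stronger inhibition of growth and higher numbers for weaker inhibition of growth. Compound 1 `COc1ccc(/C=N\NC(=S)NC(C)(C)CCC[C@](C)(O)[C@@H]2CC=C(C)CC2)cc1` gives 7660 nM. Compound 2 `CC1=CC[C@@H]([C@@](C)(O)CCCC(C)(C)NC(=S)N/N=C\c2ccc([N+](=O)[O-])cc2)CC1` gives 18100 nM; this is the highest of the two numbers, and its nearest neighbour is compound 1, reached by a 2.4-fold higher number from compound 1 to compound 2 (0.37 log units; beyond the scatter), a change of nitro in place of methoxy on an aromatic carbon.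

Compound 3 `CC1=CC[C@@H]([C@@](C)(O)CCCC(C)(C)NC(=S)N/N=C\c2ccc(Cl)cc2)CC1` is not yet measured. It differs from compound 2 by chloro in place of nitro on an aromatic carbon. Going by the values given here, no measured step exchanges nitro for chloro at this position, so the only bearing step is the one from compound 1 to compound 2, where swapping the group on the same aromatic carbon moved the read-out modestly. The expectation is therefore a step of comparable, modest size in this assay, most likely a somewhat lower number than compound 2 shows, but a change within the scatter cannot be excluded.

For compound 3 the expected value in this assay is 11000 nM, with a range from 5000 nM to 25000 nM, which means an expected step of a 1.6-fold lower number from compound 2 to compound 3 (0.22 log units; within the scatter).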

Compound 3, concentration for 50% growth inhibition: 7580 nM
The estimate for compound 3 lay 1.5-fold (0.16 log units) above the measured number, within the range that was stated.
By their numbers in this assay, from the lowest: compounds 3 and 1 (each within the scatter of the next); then compound 2.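

In this assay, the aromatic carbon para to a large group now has a direct exchange away from nitro: chloro in place of nitro gives a 2.4-fold lower number from compound 2 to compound 3 (0.38 log units; beyond the scatter) and so shows that the higher number of compound 2 does not hold once nitro leaves, whichever of the two other groups stands there. Chloro in place of methoxy gives a 1.0-fold lower number from compound 1 to compound 3 (0.00 log units; within the scatter) and so does not separate these two groups on this read-out, leaving compound 2 as the weakest of the three, with its steps to both others beyond the scatter. No independent measurement is available to account for this difference between nitro and the other two groups.

Going by these compounds alone, with only three groups at this one carbon, the data do not show whether nitro alone stands apart or whether other groups, such as an amine, a carboxylic acid or a plain hydrogen, would also separate from chloro and methoxy. Going by these compounds, whether the same exchanges would give similar steps on other carbons of the aromatic ring, or with a longer chain in the shared core, also remains open.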